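The source may report more compounds than this note shows. Statements on the series, on what has been measured and on what is new or still open speak of the compounds shown alone.

Compounds measured so far in a functional assay on Hs68 cells (Homo sapiens) for cytotoxicity; on this read-out higher numbers stand for lower toxicity in this test and lower numbers for higher toxicity in this test:
- compound 1 `C=Cc1cncc2ccc(C(=O)NCc3ccccc3OC(C)C)nc12`: 17 ug/mL
- compound 2 `Cc1cncc2ccc(C(=O)NCc3ccccc3OC(C)C)nc12`: 3 ug/mL
- compound 3 `CC(C)Oc1ccccc1CNC(=O)c1ccc2cnccc2n1`: 2.5 ug/mL

Compound 3 sits at the low end of these numbers together with compound 2, the step between them being a 1.2-fold lower number from compound 2 to compound 3 (0.08 log units; within the scatter). Compound 1 stands clear of it, with a 6.8-fold lower number from compound 1 to compound 3 (0.83 log units; beyond the scatter).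

Compound 4 `O=C(NCc1ccccc1)c1ccc2cnccc2n1` keeps the shared core of compound 3 and changes the other ring: hydrogen in place of isopropoxy on an aromatic carbon. This is hydrogen in place of isopropoxy on an aromatic carbon, ortho to a large group.

Going by the values given here, no measured step touches this place. The nearest evidence comes from changes on the core, namely a 5.7-fold lower number from compound 1 to compound 2 (0.75 log units; beyond the scatter) and the step to compound 3 already given. Among the compounds with values here, both are modest, so they show only that one change in this small set moved the read-out by a modest amount, while the swap of methyl for hydrogen did not. Any expectation for compound 4 is therefore loose. With compound 3 at the low end, a small rise seems likelier than a further fall, and a result within the scatter would fit as well.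

The expected step is a 2.0-fold higher number from compound 3 to compound 4 (0.30 log units; within the scatter). Compound 4 is estimated at 5 ug/mL, within an expected range from 1.5 ug/mL to 20 ug/mL.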

Compound 4, half-maximal cytotoxic concentration: 71 ug/mL
Estimate against measurement, compound 4: 14-fold (1.15 log units) below, and the stated range ends below it.
By their numbers in this assay, from the lowest: compounds 3 and 2 (each within the scatter of the next); then compound 1; then compound 4.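

In this assay, going by these compounds alone, hydrogen in place of isopropoxy on an aromatic carbon, ortho to a large group, gives a 28-fold higher number from compound 3 to compound 4 (1.45 log units; beyond the scatter), the only step in this small set that is printed as large. The earlier compounds shown here showed changes only on the shared core, whereas this result shows that the read-out also responds strongly to what stands on the six-membered aromatic ring of carbon only, with the loss of isopropoxy going with lower toxicity in this test. Within the data shown here, nothing given here bears on why this single change moves the number so far.

The compounds shown place only isopropoxy and hydrogen at this position, so it remains open whether a smaller methoxy, a fluorine atom or an amine there would give a number near that of compound 3, near that of compound 4 or elsewhere. It is also open whether the rise seen with vinyl on the core in compound 1 would carry over to the hydrogen-bearing ring of compound 4, since no compound shown combines the two changes.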